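Toxicity of Amine Chains: From Compound 3 to Compound 4

The source may hold more compounds than are shown below. What is called first, only, known or untested is meant among the compounds shown, and "the series" means these compounds.

Measured values in a toxicity assay on CHO cells (Cricetulus griseus) for cytotoxicity, read by WST assay, with a stated time of 24 h; on this read-out higher numbers stand for weaker inhibition and lower numbers for stronger inhibition:

Compound 1 `CC(C)=CCCC(C)=CCNCCNCCNCCNCCNCCN`: > 150000 nM (a limit)
Compound 2 `CC(C)=CCC/C(C)=C\CCC(C)=CCNCCCN`: 32100 nM
Compound 3 `CC(C)=CCC/C(C)=C\CCC(C)=CCNCCCCCN`: 38400 nM

Only compound 2 and compound 3 have numbers that can be compared. Compound 3 sits level with compound 2 within the usual scatter, as shown by a 1.2-fold higher number from compound 2 to compound 3 (0.08 log units; within the scatter) in this assay. Compound 1 reports only a limit (the limit of > 150000 nM in this assay, at which 1 of the 3 values shown sits) and gives no step size.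

Compound 4 `CC(C)=CCC/C(C)=C\CCC(C)=CCNCCCN(C)CCCN` has (3-aminopropyl)(methyl)amino in place of 2-aminoethyl on a saturated chain carbon, three bonds along the chain from an amine nitrogen. For the measured compounds named here, the one measured step that bears on this change is at the same place. That step, a 1.2-fold higher number from compound 2 to compound 3 (0.08 log units; within the scatter), put 2-aminoethyl in place of amino and moved the value by no more than the scatter. Going by the values given here, on that basis, no shift beyond the scatter is expected in this assay, though the new group is larger than the one in that step, so the range is kept wide. The expected step is a 1.0-fold higher number from compound 3 to compound 4 (0.02 log units; within the scatter) in this estimate. For compound 4 the estimated value is 40000 nM with an expected range from 16000 nM to 100000 nM in this assay.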

Compound 4, half-maximal inhibitory concentration: 10500 nM
Compound 4: the middle estimate sits 3.8-fold (0.58 log units) above what was measured; the measured number lies below the stated range.
By their numbers in this assay, from the lowest: compound 4; then compounds 2 and 3 (each within the scatter of the next). At a limit, above all of these: compound 1.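

In this assay, for the compounds shown here, the place on a saturated chain carbon, three bonds along the chain from an amine nitrogen, now shows a step beyond the scatter for the first time: (3-aminopropyl)(methyl)amino in place of 2-aminoethyl gives a 3.7-fold lower number from compound 3 to compound 4 (0.56 log units; beyond the scatter) at this place. Set against amino, the same group gives a 3.1-fold lower number from compound 2 to compound 4 (0.49 log units; beyond the scatter) and so the lower number holds against either smaller group, whereas 2-aminoethyl in place of amino had not moved the number beyond the scatter. The data shown include no measurement that accounts for this shift.

The compounds shown leave open whether the lower number belongs to the added amine nitrogen, to the methyl group on it, or simply to the longer chain. An all-carbon chain of the same length, the same chain with a secondary amine in place of the methylated one, or a longer chain carrying a further amine would be needed to tell these apart and to show whether the number keeps falling.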